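A few compounds are considered here, and "the series" means these few. Any claim that something is new, unique, unknown or untested is made for them only; others in the source may bear on it.

Within the data shown here, compound 3 `CCOc1ccc(-c2ccccc2)cc1` is one of three compounds measured in an assay on COS-7 cells for inhibition of patatin-like phospholipase domain-containing protein 2 (Mus musculus); a higher number here means a weaker inhibitor, a lower number a stronger inhibitor. Compound 1 `CCOC(=O)c1cccc(-c2ccc(O)cc2)c1` gives 100000 nM and compound 2 `CCOC(=O)c1cccc(-c2ccc(CN(C)C)cc2)c1` gives 150000 nM; the step of a 1.5-fold higher number from compound 1 to compound 2 (0.18 log units; within the scatter) concerns a different change from the one followed here. For compound 3 the assay reports only a limit, > 200000 nM, namely (the limit of > 200000 nM in this assay, at which 1 of the 3 values shown sits). Compound 4 `CCOc1ccc(-c2cccc(NC(C)=O)c2)cc1` differs from compound 3 by acetamido in place of hydrogen on an aromatic carbon. Among the measured compounds shown here, no measured step puts acetamido onto the shared core, and the only recorded step, a 1.5-fold higher number from compound 1 to compound 2 (0.18 log units; within the scatter), stayed within the scatter, so no shift beyond the scatter in this assay is expected here. Compound 4 is therefore estimated at 200000 nM, between 60000 nM and 600000 nM. The step this implies, a number no higher from compound 3 to compound 4 (the limit leaves the size open), is an expectation only.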

Compound 4, half-maximal inhibitory concentration: 200000 nM
Beside the measured number, compound 4's estimate shows no gap at the digits printed; the measured number falls inside the stated range.
By their numbers in this assay, from the lowest: compounds 1, 2 and 4 (each within the scatter of the next).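

In this assay compound 3 has only a limit, > 200000 nM. Compound 4 gives a measured number, 200000 nM, so with acetamido on this aromatic carbon the compound has a value that can be placed beside those of compounds 1 and 2. The data give a number no higher from compound 3 to compound 4 (the limit leaves the size open) as the step. The size of the change cannot be read, because compound 3 stands at a limit: the limit of > 200000 nM in this assay, at which 1 of the 4 values shown sits.

As far as these compounds go, whether a carboxylic acid or a sulfonamide at this same place would give a lower number stays open. From the compounds shown here alone, it also remains open whether any change to the shared core can move the number beyond the scatter.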